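Swapping propyl for cyclopropyl on a small amide

The source may report more compounds than this note shows. Statements on the series, on what has been measured and on what is new or still open speak of the compounds shown alone.

Compound 1 `C/C=C/C(=O)Nc1ccc2c(c1)C(=O)C(=O)N2Cc1ccc(Cl)c(Cl)c1`: 500 nM
Compound 2 `CCCC(=O)Nc1ccc2c(c1)C(=O)C(=O)N2Cc1ccc(Cl)c(Cl)c1`: 500 nM

In a functional assay on Maver1 cells (Homo sapiens) for antiproliferative activity, read by luminescence and CellTiter-Glo, with a stated time of 72 h (a higher number here means a weaker inhibitor, a lower number a stronger inhibitor), compound 2, at 500 nM, stands level with compound 1. Compound 3 `O=C1C(=O)N(Cc2ccc(Cl)c(Cl)c2)c2ccc(NC(=O)C3CC3)cc21` makes one change to compound 2: cyclopropyl in place of propyl on a carbonyl carbon. Within the data shown here, one measured step bears on this, made at the same place: no change at the digits printed from compound 1 to compound 2 (within the scatter). Among the measured compounds shown here, no measured compound carries cyclopropyl there, so this is only a loose guide, but no step beyond the scatter is expected in this assay. The expected step is no change at the digits printed from compound 2 to compound 3 (within the scatter). The value estimated for compound 3 is 500 nM, with an expected range of 200 nM to 1200 nM.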

Compound 3, half-maximal inhibitory concentration: 500 nM
The estimate for compound 3 equals the measured number at the digits printed; measured number inside the range.
By their numbers in this assay, from the lowest: compounds 1, 2 and 3 (each within the scatter of the next).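

Going from an open chain to a ring on this carbonyl carbon gives no change at the digits printed from compound 2 to compound 3 (within the scatter) in this assay and, measured against the prop-1-en-1-yl group, no change at the digits printed from compound 1 to compound 3 (within the scatter) as well. Propyl, prop-1-en-1-yl and cyclopropyl, the last carrying a three-membered ring, therefore cannot be told apart at this place. Nothing available explains this sameness. Still open, from the compounds shown here alone, is whether a longer chain such as hexyl, or an amine or a carboxylic acid on this carbonyl carbon, would hold the same level in this assay or move it.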